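Opening the Ring: From Piperazine to Dimethylamino

A few compounds are considered here, and "the series" means these few. Any claim that something is new, unique, unknown or untested is made for them only; others in the source may bear on it.

Compound 2 `CN1CCN(CCCOc2ccc3c(c2)N(Cc2ccccc2)C(=O)CC3)CC1` and compound 1 `CC1CCN(CCCOc2ccc3c(c2)N(Cc2ccccc2)C(=O)CC3)CC1` share a core and differ only in the basic group at the end of the chain. Among the measured compounds shown here, in an assay on cell membranes (strain Dunkin Hartley) for displacement of a labelled ligand from Sigma non-opioid intracellular receptor 1 (Cavia porcellus), read by scintillation counting, with a stated time of 180 min (on this read-out lower numbers stand for stronger inhibition and higher numbers for weaker inhibition), compound 1 gives 1.1 nM, while compound 2 gives 4.3 nM, the higher of the two numbers measured so far; the step of a 3.9-fold higher number from compound 1 to compound 2 (0.59 log units; beyond the scatter) is the single comparison available. Compound 3 `CN(C)CCCOc1ccc2c(c1)N(Cc1ccccc1)C(=O)CC2` changes the same place again: dimethylamino in place of 4-methylpiperazin-1-yl on a saturated chain carbon, three bonds along the chain from an oxygen on an aromatic ring. For the measured compounds named here, no measured step involves a dimethylamino group, so the earlier step shows only that swapping one ring amine for another there moved the number modestly. A shift of similar or somewhat larger size is expected, most likely toward a higher number, so for compound 3 the expected step is a 2.1-fold higher number from compound 2 to compound 3 (0.32 log units; beyond the scatter). The value expected for compound 3 in this assay is 9 nM, within a range of 2.5 nM to 35 nM.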

Compound 3, inhibition constant: 83.2 nM
The estimate for compound 3 lay 9.2-fold (0.97 log units) below the measured number, outside the stated range (above it).
By their numbers in this assay, from the lowest: compound 1; then compound 2; then compound 3.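

In this assay the change to an open-chain amine has a large effect: the piece shows a 19-fold higher number from compound 2 to compound 3 (1.29 log units; beyond the scatter) and also a 76-fold higher number from compound 1 to compound 3 (1.88 log units; beyond the scatter) while the swap between the two ring amines gave only a 3.9-fold higher number from compound 1 to compound 2 (0.59 log units; beyond the scatter) as a modest step. This position at the end of the chain therefore accepts one ring amine in place of the other far better than it accepts dimethylamino, with its 3 heavy atoms and no ring, in place of 4-methylpiperazin-1-yl, with 7 heavy atoms and one ring. Nothing measured here explains this loss.

Compound 3 loses the ring and heavy atoms together, so the compounds shown cannot separate those two changes. A diethylamino group, which has no ring, and a pyrrolidin-1-yl ring could help to tell them apart.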